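This account rests on a few compounds, and the source may have more. Where it says the series, first, only, none or still open, it means among the compounds named here.

Values so far in an ADME assay (liver) for metabolic stability, with Liver microsome (Homo sapiens) as the target, read by LC-MS, using microsomes and NADPH, with a stated time of 5 min, at 37 degrees C; on this read-out higher numbers stand for fast clearance and lower numbers for slow clearance:
Compound 1 `CCn1c([C@@H](C)NS(=O)(=O)c2ccc(Cl)cc2)nc2ccccc21` gives > 100 mL.min-1.g-1 as a limit of the assay
Compound 2 `CCn1c([C@@H](C)NS(=O)(=O)c2ccc(Cl)cc2)nc2ccc(CN(C)C)cc21` gives 30 mL.min-1.g-1
Compound 3 `CCn1c([C@@H](C)NS(=O)(=O)c2ccc(C#N)cc2)nc2ccc(C(F)(F)F)cc21` gives 34 mL.min-1.g-1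

Compound 3 lies within the scatter of compound 2, and compound 1 offers only a limit for comparison. Compound 4 `CCn1c([C@@H](C)NS(=O)(=O)c2ccccn2)nc2ccc(C(F)(F)F)cc21` differs from compound 3 as follows: pyridin-2-yl in place of 4-cyanophenyl on a sulfonyl sulfur and the rest of the structure stays the same. Going by the values given here, the only measured step is an at least 3.3-fold lower number from compound 1 to compound 2 (0.52 log units; beyond the scatter) and it concerns (dimethylamino)methyl in place of hydrogen on an aromatic carbon. Its size is only a bound because the limit of > 100 mL.min-1.g-1 in this assay, at which 1 of the 3 values shown sits, applies to compound 1 . Among the compounds with values here, no measured step changes the group on the sulfonyl sulfur, so that step sets no size for this one. The estimate therefore starts from compound 3 with 34 mL.min-1.g-1 as its anchor. The expected change is a 1.2-fold lower number from compound 3 to compound 4 (0.08 log units; within the scatter) and no step beyond the scatter is expected. In this assay compound 4 is expected at 28 mL.min-1.g-1 with an estimated range from 11 mL.min-1.g-1 to 70 mL.min-1.g-1.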

Compound 4, intrinsic clearance in microsomes: < 3 mL.min-1.g-1
Compound 4 gave a limit, no number; the forecaster's own chance of this, stated with the estimate: 8%; middle value at least 9.3-fold (0.97 log units) from the limit.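

In this assay, the group on the sulfonyl sulfur proves a strong handle on clearance: pyridin-2-yl in place of 4-cyanophenyl gives an at least 11-fold lower number from compound 3 to compound 4 (1.05 log units; beyond the scatter), with the rest of the structure unchanged. Going by these compounds alone, the earlier compounds offered no step at this position, and their only step lay on an aromatic carbon of the shared core. Compound 4 sits at a limit of the assay, so the size of this step is only a bound: the limit of < 3 mL.min-1.g-1 in this assay, at which 1 of the 4 values shown sits.

Within the data shown here, the single exchange does not separate the loss of the nitrile from the entry of the ring nitrogen, and an unsubstituted phenyl on the sulfonyl sulfur would bear on that question. Also open, from the compounds shown here alone, is whether pyridin-2-yl acts to the same extent with (dimethylamino)methyl on the core in place of trifluoromethyl.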